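Replacing a bicyclic amide group with methoxyphenyl

The compounds below may be only part of what the source reports. "The series", "measured", "known", "first", "only" and "open" are said of these compounds alone.

Compound 1, `O=C(Nc1ccc2[nH]c(=O)[nH]c2c1)[C@H]1CCCN1C(=O)C1(c2cccc(Cl)c2)CCCC1`, gives 0.398 nM in an assay on isolated protein for inhibition of histone acetyltransferase p300 (Homo sapiens), with a stated time of 60 min; a lower number here means a stronger inhibitor, a higher number a weaker inhibitor.
Compound 2, `O=C1Cc2cc(NC(=O)[C@H]3CCCN3C(=O)C3(c4cccc(Cl)c4)CCCC3)ccc2N1`, gives 0.794 nM in this assay.
Compound 3, `COc1ccc(NC(=O)[C@H]2CCCN2C(=O)C2(c3ccc(Cl)cc3)CCC2)cc1`, gives 10 nM in this assay.

Among these three numbers compound 2 stands second highest. Its nearest neighbour is compound 1, reached by a 2.0-fold higher number from compound 1 to compound 2 (0.30 log units; within the scatter), a step that lies within the scatter, so the two cannot be ordered. Its furthest neighbour is compound 3, whose number is clearly higher and beyond the scatter.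

Compound 4, `COc1ccc(NC(=O)[C@H]2CCCN2C(=O)C2(c3cccc(Cl)c3)CCCC2)cc1`, differs from compound 2 in one place: a group of 8 heavy atoms (7 carbon, 1 oxygen; one six-membered aromatic ring of carbon only) in place of a group of 10 heavy atoms (8 carbon, 1 nitrogen, 1 oxygen; one five-membered non-aromatic ring with 1 hetero atom, one six-membered aromatic ring of carbon only), on an amide-type nitrogen. Going by the values given here, no measured step covers this exact change. Among the compounds with values here, the one measured step, a 2.0-fold higher number from compound 1 to compound 2 (0.30 log units; within the scatter), exchanges one bicyclic group for another and stays within the scatter, so it does not speak to removing such a group altogether. Compound 3 carries the same 4-methoxyphenyl as compound 4, but it also differs from compound 2 in where the chlorine sits and in the size of the saturated ring, so only its two values can be set side by side: compound 3 sits well above compound 2. On that basis compound 4 is expected to give a weaker result, with a step of about a 6.3-fold higher number from compound 2 to compound 4 (0.80 log units; beyond the scatter) from compound 2. The estimate for compound 4 is 5 nM, expected to fall between 1.5 nM and 16 nM.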

Compound 4, half-maximal inhibitory concentration: 100 nM
The estimate for compound 4 lay 20-fold (1.30 log units) below the measured number; measured number outside the range, above it.
By their numbers in this assay, from the lowest: compounds 1 and 2 (each within the scatter of the next); then compound 3; then compound 4.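

Swapping either bicyclic group on the amide-type nitrogen for 4-methoxyphenyl costs a great deal in this assay: the change gives a 130-fold higher number from compound 2 to compound 4 (2.10 log units; beyond the scatter) and a 250-fold higher number from compound 1 to compound 4 (2.40 log units; beyond the scatter). Going by these compounds alone, the earlier step showed only that one bicyclic group could stand in for the other, whereas these two large steps show that this position does not accept every aromatic group, and that both bicyclic groups give much stronger inhibition than this single-ring group on the same core. The group that leaves compound 2 carries 1 hydrogen-bond donor and 4-methoxyphenyl carries 0, but that count is only one of several differences between the two groups, and nothing measured here explains the large loss.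

With 4-methoxyphenyl as the only single-ring group on this core, the compounds shown leave open whether the loss follows the removal of the second ring or the removal of the ring nitrogen with its hydrogen. Within the data shown here, they also leave open whether an amine or a carboxylic acid in place of the methoxy group would bring the number back toward the one compound 2 gives, 0.794 nM.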